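The source may hold more compounds than are shown below. What is called first, only, known or untested is meant among the compounds shown, and "the series" means these compounds.

Compound 1 `COc1ccc(F)c(CNC(C)=O)c1`, compound 2 `CCC(=O)NCc1cc(OC)ccc1F` and compound 3 `CCC(=O)NCc1ccc(F)c(OC)c1` share an amide on a fluorinated, methoxy-bearing ring and were tested in an assay on isolated protein for agonist activity at melatonin receptor type 1C (Xenopus laevis), read by spectrophotometry; on this read-out higher numbers stand for an effect only at larger amounts of compound and lower numbers for an effect already at smaller amounts. In this assay compound 1 gives 1950 nM, compound 2 gives 2400 nM and compound 3 gives 2880 nM. Compound 2 arises from compound 1 by methyl in place of hydrogen on a saturated chain carbon bound to a carbonyl carbon, which gave a 1.2-fold higher number from compound 1 to compound 2 (0.09 log units; within the scatter). How the core of compound 3 differs from the core of compound 1 is not broken down here. Compound 4 `CCCC(=O)NCc1ccc(F)c(OC)c1`, still unmeasured, arises from compound 3 by methyl in place of hydrogen on a saturated chain carbon, two bonds along the chain from a carbonyl carbon, the same kind of change as from compound 1 to compound 2, though there the methyl entered on a saturated chain carbon bound to a carbonyl carbon, while here it enters on a saturated chain carbon, two bonds along the chain from a carbonyl carbon. Because the earlier change gave a 1.2-fold higher number from compound 1 to compound 2 (0.09 log units; within the scatter), the expected step is a 1.1-fold higher number from compound 3 to compound 4 (0.06 log units; within the scatter). In this assay compound 4 is estimated at 3300 nM, likely between 1600 nM and 7000 nM.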

Compound 4, half-maximal effective concentration: 2510 nM
For compound 4 the middle estimate is 1.3-fold (0.12 log units) above the measured one; measured number inside the range.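

In this assay, the methyl added on a saturated chain carbon, two bonds along the chain from a carbonyl carbon, gives a 1.1-fold lower number from compound 3 to compound 4 (0.06 log units; within the scatter). Set beside the earlier methyl step, the two cores show no difference that can be told from the scatter: the same change on two cores in this assay, a 1.2-fold higher number (0.09 log units; within the scatter) from compound 1 to compound 2 and a 1.1-fold lower number (0.06 log units; within the scatter) from compound 3 to compound 4, 1.4-fold (0.15 log units) apart, within the scatter of two such steps. Going by these compounds alone, this shows only that neither methyl step stands out from the scatter on these two cores; it does not show that the same would hold on other cores, and the two methyls also enter at different places on the chain.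

The compounds shown leave open what a longer chain would do in place of propylcarbonyl. They also leave open what an amine or a carboxylic acid in that place would do.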